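The source may report more compounds than this note shows. Statements on the series, on what has been measured and on what is new or still open speak of the compounds shown alone.

Measured so far:
compound 1 `CC(C)N1CCN(S(=O)(=O)CCCN2CCC(CNC(=O)c3cccc4c3OCCO4)CC2)CC1` — 0.0316 nM
compound 2 `CC(C)S(=O)(=O)N1CCN(S(=O)(=O)CCCN2CCC(CNC(=O)c3cccc4c3OCCO4)CC2)CC1` — 0.126 nM

Both numbers come from an assay on isolated protein for inhibition of 5-hydroxytryptamine receptor 4 (Homo sapiens); on this read-out lower numbers stand for stronger inhibition and higher numbers for weaker inhibition. Compound 2 stands highest of the two: the step of a 4.0-fold higher number from compound 1 to compound 2 (0.60 log units; beyond the scatter) is beyond the scatter, so compound 2 is the weaker binder. Compound 3 `O=C(NCC1CCN(CCCS(=O)(=O)N2CCN(S(=O)(=O)c3ccc(F)cc3)CC2)CC1)c1cccc2c1OCCO2` is not yet measured. It differs from compound 2 by 4-fluorophenyl in place of isopropyl on a sulfonyl sulfur. For the measured compounds named here, no measured step exchanges a group on this sulfonyl sulfur; the only known step altered what sits on the ring nitrogen instead, so it bears only loosely on this change. The expected step of a 1.6-fold higher number from compound 2 to compound 3 (0.20 log units; within the scatter) is therefore within the scatter, and compound 3 is estimated at 0.2 nM with a range from 0.04 nM to 1 nM.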

Compound 3, inhibition constant: 0.0316 nM
Estimate against measurement, compound 3: 6.3-fold (0.80 log units) above; the measured number lies below the stated range.
By their numbers in this assay, from the lowest: compounds 1 and 3 (each within the scatter of the next); then compound 2.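

Changing the group on the sulfonyl sulfur shifts binding beyond the scatter (a 4.0-fold lower number from compound 2 to compound 3 (0.60 log units; beyond the scatter)), so this position is sensitive to what it carries. A sulfonyl on the ring nitrogen also need not cost binding: with 4-fluorophenyl on the sulfur, the result matches the isopropyl amine (no change at the digits printed from compound 1 to compound 3 (within the scatter)). Nothing available explains why these groups differ. Still open, going by these compounds, is whether the ring or its fluorine accounts for the difference from isopropyl; an unsubstituted phenyl on the sulfonyl sulfur would separate the two.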